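A few compounds are considered here, and "the series" means these few. Any claim that something is new, unique, unknown or untested is made for them only; others in the source may bear on it.

Compound 2 `CCCCc1nc(C)c(CC(=O)OCC(C)C)c(=O)n1Cc1ccc(-c2ccccc2-c2noc(=O)[nH]2)cc1` gives 2.4% in an ADME assay on microsomes from liver (Homo sapiens) for metabolic stability, with a stated time of 30 min (a higher number here means that more of the compound is left, a lower number that less of the compound is left), the lowest of the two numbers at hand. Compound 1 `CCCCc1nc(C(C)C)c(CC(=O)OCC(C)C)c(=O)n1Cc1ccc(-c2ccccc2-c2noc(=O)[nH]2)cc1` gives 8.8% in this assay, and the step of a number 6.4 percentage points lower from compound 1 to compound 2 (within the scatter) lies within the scatter. Compound 3 `CC#CCOC(=O)Cc1c(C)nc(CCCC)n(Cc2ccc(-c3ccccc3-c3noc(=O)[nH]3)cc2)c1=O` differs from compound 2 by prop-1-yn-1-yl in place of isopropyl on a saturated chain carbon bound to an oxygen next to a carbonyl group. Going by the values given here, no measured step touches this ester side chain; the only known step, a number 6.4 percentage points lower from compound 1 to compound 2 (within the scatter), concerns the substituent on the aromatic carbon. Hence no change beyond the scatter is expected. For compound 3 the estimate is 3%, with a range from 0.5% to 12%. The expected step is a number 0.6 percentage points higher from compound 2 to compound 3 (within the scatter), within the scatter.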

Compound 3, percent of the compound remaining: 32%
Estimate against measurement, compound 3: 29 percentage points below, and the stated range ends below it.
By their numbers in this assay, from the lowest: compounds 2 and 1 (each within the scatter of the next); then compound 3.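

Going by these compounds alone, the ester side chain is a position that moves the read-out in this assay, with prop-1-yn-1-yl in place of isopropyl giving a number 29.6 percentage points higher from compound 2 to compound 3 (beyond the scatter), while the only earlier step, a number 6.4 percentage points lower from compound 1 to compound 2 (within the scatter), concerned the aromatic carbon. The step comes with a triple bond at an unchanged heavy-atom count. No evidence at hand bears on its origin.

As far as these compounds go, whether the triple bond alone carries the step stays open, since a saturated straight butyl ester would be needed to separate it from chain shape. Also open, from the compounds shown here alone, is how a longer alkynyl chain, or an amide in place of the ester, would behave.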